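Shortening the side chain on the shared core

The compounds below may be only part of what the source reports. "The series", "measured", "known", "first", "only" and "open" are said of these compounds alone.

Of the compounds shown here, two have been tested in a functional assay on the whole organism for inhibition, with Lepidium sativum as the target, tested at 1 ppm; a lower number here means less inhibition of growth, a higher number more inhibition of growth at the concentration tested. Compound 1 `COC(=O)C(C)ON1C(=O)c2ccccc2C1=O` gives 64% in this assay. Compound 2 `CCCCCCC(ON1C(=O)c2ccccc2C1=O)C(=O)OCC` gives 0% in this assay, the lowest of the two numbers; its nearest neighbour is compound 1, whose value lies far higher, beyond the scatter. The two differ in more than one place, so only the two values themselves can be compared.

Compound 3 `CCOC(=O)C(C)ON1C(=O)c2ccccc2C1=O` has not yet been measured. It differs from compound 2 in a single place: hydrogen in place of pentyl on a saturated chain carbon, two bonds along the chain from a carbonyl carbon and an oxygen on an unsaturated carbon. Compound 3 thereby carries the same short side chain as compound 1 and shares the ethyl ester of compound 2.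

For the measured compounds named here, no step between measured compounds isolates this change. Since compound 1 with the methyl side chain gives 64%, a rise in this assay from compound 2 to compound 3 is expected, beyond the scatter. The estimated step of a number 55 percentage points higher from compound 2 to compound 3 (beyond the scatter) is expected to bring compound 3 close to compound 1. For compound 3 the estimate in this assay is 55%, within a range from 25% to 75%.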

Compound 3, percent growth inhibition at one concentration: 68%
Compound 3: the middle estimate sits 13 percentage points below what was measured, and the stated range covers the measured number.
By their numbers in this assay, from the lowest: compound 2; then compounds 1 and 3 (each within the scatter of the next).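

For the compounds shown here, with the ethyl ester held constant, the exchange of hexyl for methyl at this position, read one bond further in as hydrogen in place of pentyl, is the first single change isolated, and in this assay it gives a number 68 percentage points higher from compound 2 to compound 3 (beyond the scatter). The side chain at this position therefore carries a large effect on growth inhibition at the concentration tested, a dependence that the comparison of compounds 1 and 2 could not assign to one place, since they also differ in the ester. The ester itself makes no readable difference at the methyl side chain: methyl in place of hydrogen on a saturated chain carbon bound to an oxygen next to a carbonyl group gives a number 4 percentage points higher from compound 1 to compound 3 (within the scatter), and no measurement at hand explains either step.

Only methyl and hexyl side chains are shown at this position, so it remains open whether inhibition falls gradually or abruptly across intermediate chains such as propyl or butyl. Also open, on these data alone, is how a carboxylic acid or an amide in place of the ester would read in this assay, and whether the ester's silence holds on the hexyl side chain.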